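From 4-pentylphenyl to tert-butyl: an expected loss of activity

The compounds below may be only part of what the source reports. "The series", "measured", "known", "first", "only" and "open" are said of these compounds alone.

Among the compounds with values here, in a functional assay on SW-620 cells (Homo sapiens) for antiproliferative activity, read by MTT assay, with a stated time of 72 h (a higher number here means a weaker inhibitor, a lower number a stronger inhibitor), compound 1 `CCCCCc1ccc(-c2cn(C[C@H](O)[C@H]3OC(=O)C(OCc4ccccc4)=C3OCc3ccccc3)nn2)cc1` gives 12200 nM, the only actual number in this small series. Compound 2 `CC(C)(C)OC(=O)N1CCN(C(=S)SCc2cn(C[C@H](O)[C@H]3OC(=O)C(OCc4ccccc4)=C3OCc3ccccc3)nn2)CC1` gives only a limit, > 100000 nM. Compound 3 `COc1ccc(-c2cn(C/C=C3\OC(=O)C(OCc4ccccc4)=C3OCc3ccccc3)nn2)cc1` also gives only a limit, > 100000 nM. The main feature of the data so far is therefore (the limit of > 100000 nM in this assay, at which 2 of the 3 values shown sit).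

Compound 4 `CC(C)(C)c1cn(C[C@H](O)[C@H]2OC(=O)C(OCc3ccccc3)=C2OCc2ccccc2)nn1` keeps the core of compound 1 but carries tert-butyl in place of 4-pentylphenyl on an aromatic carbon. Within the data shown here, no measured pair of compounds shows the size of such a change. Among the measured compounds shown here, the only number to lean on is that of compound 1, 12200 nM, and no measured compound lies on the stronger side of it. A step towards weaker inhibition, beyond the scatter, is thus expected in this assay. The expected step is a 4.1-fold higher number from compound 1 to compound 4 (0.61 log units; beyond the scatter). For compound 4 the estimated value is 50000 nM, with an expected range of 15000 nM to 100000 nM.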

Compound 4, half-maximal inhibitory concentration: 35800 nM
Beside the measured number, compound 4's estimate is 1.4-fold (0.15 log units) above it, within the range that was stated.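

In this assay, replacing 4-pentylphenyl with tert-butyl on this aromatic carbon gives a 2.9-fold higher number from compound 1 to compound 4 (0.47 log units; beyond the scatter), the first measured size for a change at this position. This modest step shows that the group can lose its six-membered aromatic ring and much of its heavy-atom count while compound 4 still gives a readable number. Compound 4 therefore stays clear of the assay limit that marks the other side of this small series: the limit of > 100000 nM in this assay, at which 2 of the 4 values shown sit.

From the compounds shown here alone, what a plain phenyl group or an unbranched pentyl chain would give at this position remains open, so the shares of the ring and the chain in the step cannot be separated. Going by these compounds, it is equally open how an amine or a carboxylic acid in place of tert-butyl would behave.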